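Trimming the Oxime Ether: From Compound 1 to Compound 4

The compounds below may be only part of what the source reports. "The series", "measured", "known", "first", "only" and "open" are said of these compounds alone.

Compound 1 `C/C(=N\OCc1ccncc1)c1ccc(Sc2cc(F)cc(C3CCOCC3)c2)cc1` was examined in a functional assay (blood) for inhibition, with Homo sapiens as the target (a lower number here means a stronger inhibitor, a higher number a weaker inhibitor), where compound 1 gives 300 nM. Among the three compounds measured so far, compound 1 carries the highest number. For the measured compounds named here, compound 3 `COC1(c2cc(F)cc(Sc3ccc4c(c3)CC/C4=N\O)c2)CCOCC1` gives 290 nM in this assay, a value that lies within the scatter of the one for compound 1, so the two cannot be ordered. Compound 2 `COC1(c2cc(F)cc(Sc3ccc4c(c3)OCC/C4=N\OCC#N)c2)CCOCC1` gives 40 nM in this assay, a number well below that of compound 1 and beyond the scatter. Going by the values given here, compounds 2 and 3 differ from compound 1 in more than one place, and no pair of the measured compounds is joined by a change in one place alone.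

Compound 4 `CO/N=C(\C)c1ccc(Sc2cc(F)cc(C3CCOCC3)c2)cc1` has not been measured. It differs from compound 1 in one place: hydrogen in place of pyridin-4-yl on a saturated chain carbon bound to an oxygen. Among the compounds with values here, no measured pair shows what this change does here, so the expectation rests on the change itself. For compound 4 the step of a 2.0-fold higher number from compound 1 to compound 4 (0.30 log units; within the scatter) is expected to run toward a higher number, though it may not clear the scatter. Compound 4 is expected to give 600 nM in this assay, within a range from 200 nM to 2000 nM.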

Compound 4, half-maximal inhibitory concentration: 110 nM
Beside the measured number, compound 4's estimate is 5.5-fold (0.74 log units) above it; measured number outside the range, below it.
By their numbers in this assay, from the lowest: compound 2; then compound 4; then compounds 3 and 1 (each within the scatter of the next).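

In this assay, for the compounds shown here, the step of a 2.7-fold lower number from compound 1 to compound 4 (0.44 log units; beyond the scatter) is the first reading of a change in one place, and it is modest but beyond the scatter. It shows that pyridin-4-yl, on a saturated chain carbon bound to an oxygen, is not required for inhibition on this core, since the plain methoxy group, with hydrogen in that place, gives the lower number. No measurement is at hand that would explain this step.

The compounds shown leave open whether the pyridine nitrogen or the ring as a whole accounts for the step, which a phenyl group in the same place would address. They also leave open how a longer chain, an amine or a carboxylic acid would read there, and whether the step carries over to other cores.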